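Bromo in place of fluoro on compound 1

This account rests on a few compounds, and the source may have more. Where it says the series, first, only, none or still open, it means among the compounds named here.

- compound 1 `C=CCOc1ccc(F)cc1C(=O)c1cccnc1` gives > 100000 nM
- compound 2 `O=C(c1cccnc1)c1cc(F)ccc1O` gives 12000 nM
- compound 3 `O=C(c1cccnc1)c1cc(Cl)ccc1O` gives 27000 nM

In a functional assay on Hep cells (Homo sapiens) for cytotoxicity, read by sulforhodamine B assay, with a stated time of 48 h (a higher number here means a weaker inhibitor, a lower number a stronger inhibitor), compound 1 stands at > 100000 nM, which is a limit of the assay and not a number.

Compound 4 `C=CCOc1ccc(Br)cc1C(=O)c1cccnc1` keeps the allyloxy group of compound 1 and differs from it in one place: bromo in place of fluoro on an aromatic carbon, para to an allyloxy group (bromo in place of fluoro on an aromatic carbon). For the measured compounds named here, no measured step makes this exact exchange. The nearest is the exchange of one halogen for another in the compounds without the allyl group, a 2.3-fold higher number from compound 2 to compound 3 (0.35 log units; beyond the scatter), which is modest in size. The other measured step, an at least 8.3-fold lower number from compound 1 to compound 2 (0.92 log units; beyond the scatter), concerns the allyl group and not the halogen, and compound 4 keeps that group.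

The direction of the expectation therefore rests on compound 3, reached by a 2.3-fold higher number from compound 2 to compound 3 (0.35 log units; beyond the scatter). In this assay a modest move toward a higher number is expected, or none beyond the scatter, and compound 4 may well be reported only as a limit too. The expected change is a step that the limit leaves unreadable from compound 1 to compound 4. For compound 4 the estimated value is 130000 nM. The estimated range for compound 4 runs from 45000 nM to 300000 nM.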

Compound 4, half-maximal inhibitory concentration: 78000 nM
Compound 4: middle estimate off by 1.7-fold (0.22 log units), on the high side; the measured number falls inside the stated range.
By their numbers in this assay, from the lowest: compound 2; then compound 3; then compound 4. At a limit, above all of these: compound 1.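

In this assay compound 4 gives a readable number with the allyloxy group still in place, so an exchange of halogen on this aromatic carbon, para to an allyloxy group, can now be followed in a compound that keeps that group, which compound 2 and compound 3 could not show. Compound 1 stands at > 100000 nM as a limit of the assay and not a number. The exchange of fluoro for bromo can therefore be read only as an at least 1.2-fold lower number from compound 1 to compound 4 (0.10 log units; that floor lies within the scatter) and gives no firm size or direction, because the comparison starts from that limit: the limit of > 100000 nM in this assay, at which 1 of the 4 values shown sits.

The compounds shown leave open whether bromo on the core without the allyl group would continue the halogen step seen between the two compounds that carry a free hydroxyl, and whether chloro would behave like bromo when the allyloxy group is kept. They also leave open what a longer chain on that oxygen, or an amine or a carboxylic acid at the end of such a chain, would do to the number in this assay.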